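Notes on compound 3: thiazolyl for trifluoromethylphenyl

This account rests on a few compounds, and the source may have more. Where it says the series, first, only, none or still open, it means among the compounds named here.

Two members of the series have been run in a toxicity assay on Vero cells (Chlorocebus sabaeus) for cytotoxicity; a lower number here means that less compound is tolerated, a higher number that more compound is tolerated. Compound 1 `COc1ncc(-c2ccccc2)cc1[C@@H](c1ccccc1)[C@@](O)(CCN(C)C)c1cc(F)ccc1F` gives > 50 ug/mL, which is a limit of the assay and not a number. Compound 2 `COc1nc(-c2ccc(C(F)(F)F)cc2)ccc1[C@@H](c1ccccc1)[C@@](O)(CCN(C)C)c1cccc2ccccc12` likewise returns only a limit, > 50 ug/mL. Both readings therefore sit at the limit of > 50 ug/mL in this assay, at which 2 of the 2 values shown sit, and compound 2 stands at that limit with no numeric value that would place it relative to compound 1.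

Compound 3 `COc1nc(-c2cnsc2)ccc1[C@@H](c1ccccc1)[C@@](O)(CCN(C)C)c1cccc2ccccc12` is not yet measured in this assay. It differs from compound 2 by 1,2-thiazol-4-yl in place of 4-(trifluoromethyl)phenyl on an aromatic carbon: one aromatic group exchanged for another at the same place. Among the measured compounds shown here, no step between measured compounds has been quantified in this assay, so no direction can be read from the data. With compound 2 reported at the limit > 50 ug/mL, no step beyond the scatter is expected for compound 3 in this assay. Compound 3 is estimated at 60 ug/mL, within 30 ug/mL to 120 ug/mL, and is most likely to be reported again only as a limit. The estimated step is a step that the limit leaves unreadable from compound 2 to compound 3, none beyond the scatter.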

Compound 3, half-maximal cytotoxic concentration: 26.3 ug/mL
Estimate against measurement, compound 3: 2.3-fold (0.36 log units) above, and the stated range ends above it.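

In this assay, among the compounds shown here, compound 3 gives 26.3 ug/mL, the first reading that is a number and not a limit of the assay. On the aromatic carbon next to the ring nitrogen and para to a large group, 1,2-thiazol-4-yl in place of 4-(trifluoromethyl)phenyl gives an at least 1.9-fold lower number from compound 2 to compound 3 (0.27 log units; that floor lies within the scatter), so a single exchange at this place is enough to bring a reading inside the measurable range, though the floor of the step does not go beyond the scatter. The true size of the step stays unknown because compound 2 sits at a limit: the limit of > 50 ug/mL in this assay, at which 2 of the 3 values shown sit.

The exchange alters ring size, hetero atoms and the trifluoromethyl group together, so the compounds shown cannot say which of these goes with the lower number, and they give no cause for it. As far as these compounds go, how a pyridyl ring, a plain phenyl or a primary amine at this same place would read in this assay stays open, as does whether the same exchange on another core would give a similar reading.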